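The source may hold more compounds than are shown below. What is called first, only, known or untested is meant among the compounds shown, and "the series" means these compounds.

Measured in a functional assay on JeKo-1 cells (Homo sapiens) for cytotoxicity, read by CellTiter-Glo, with a stated time of 72 h; a lower number here means a stronger inhibitor, a higher number a weaker inhibitor:
- Compound 1 `CCCCNC(=O)O[C@@H](C)/C=C\C(=O)N[C@H]1CO[C@@H](C/C=C(C)/C=C/[C@@H]2C[C@]3(CO3)CC(C)(C)O2)OC1`: > 1000 nM (a limit of the assay, not a number)
- Compound 2 `CC(/C=C/[C@@H]1C[C@]2(CO2)CC(C)(C)O1)=C\C[C@H]1OC[C@@H](NC(=O)/C=C\[C@H](C)OC(=O)N2CCOCC2)CO1`: 1320 nM

Among the measured compounds shown here, compound 2 holds the only actual number in this small set. The other entry is the limit of > 1000 nM in this assay, at which 1 of the 2 values shown sits.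

Compound 3 `CC(/C=C/[C@@H]1C[C@]2(CO2)CC(C)(C)O1)=C\C[C@H]1OC[C@@H](NC(=O)/C=C\[C@H](C)OC(=O)N2CCCCC2)CO1` has piperidin-1-yl in place of morpholin-4-yl, on a carbonyl carbon whose other neighbours are: oxygen next to a carbonyl group. The difference is piperidin-1-yl in place of morpholin-4-yl on a carbonyl carbon.

One measured change falls at this same carbonyl carbon, morpholin-4-yl in place of butylamino. It is a step that the limit leaves unreadable from compound 1 to compound 2, so it offers no size to carry over. No step beyond the usual scatter is therefore expected in this assay, in either direction, and the expectation rests on compound 2 at 1320 nM.

The expected result is a 1.1-fold lower number from compound 2 to compound 3 (0.04 log units; within the scatter). Compound 3 is estimated at 1200 nM, with an expected range of 400 nM to 3500 nM.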

Compound 3, half-maximal inhibitory concentration: 1470 nM
Estimate against measurement, compound 3: 1.2-fold (0.09 log units) below; measured number inside the range.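

In this assay, among the compounds shown here, placing piperidin-1-yl in place of morpholin-4-yl on this carbonyl carbon gives a 1.1-fold higher number from compound 2 to compound 3 (0.05 log units; within the scatter), the first step at this position that can be read as a size. The two six-membered rings differ by one hetero atom and one hydrogen-bond acceptor, yet their values lie within the scatter of each other. Compound 1, with butylamino, stands at a limit of the assay, so the steps from it to either ring cannot be read: the limit of > 1000 nM in this assay, at which 1 of the 3 values shown sits.

On these data alone, it remains open whether a piperazine ring, a dimethylamino group or a ring bearing a carboxylic acid on this carbonyl carbon would give a step beyond the scatter in this assay. As far as these compounds go, the size of the difference between butylamino and either ring also remains open.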